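From an Ethoxy to a Propargyloxy Group

The compounds below may be only part of what the source reports. "The series", "measured", "known", "first", "only" and "open" are said of these compounds alone.

compound 1 `COc1ccc([C@@H]2CC(=O)c3cc(CC=C(C)C)c(OC)cc3O2)cc1`: 68%
compound 2 `COc1cc2c(cc1CC=C(C)C)C(=O)C[C@@H](c1ccc(Oc3cccc([N+](=O)[O-])c3)cc1)O2`: 46%
compound 3 `CCOc1ccc([C@@H]2CC(=O)c3cc(CC=C(C)C)c(OC)cc3O2)cc1`: 65%

In a functional assay on HCT-116 cells (Homo sapiens) for inhibition, read by sulforhodamine B assay, with a stated time of 48 h, tested at 50 uM (a higher number here means more inhibition of growth at the concentration tested, a lower number less inhibition of growth), compound 3 gives 65%. That matches compound 1 within the scatter and lies above compound 2 beyond it.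

Compound 4 `C#CCOc1ccc([C@@H]2CC(=O)c3cc(CC=C(C)C)c(OC)cc3O2)cc1` differs from compound 3 in one place: ethynyl in place of methyl on a saturated chain carbon bound to an oxygen on an aromatic ring. This is ethynyl in place of methyl, turning ethoxy into propargyloxy.

Two measured changes on the same oxygen on an aromatic ring bear on this. Swapping a methyl for a short chain did little, as a number 3 percentage points lower from compound 1 to compound 3 (within the scatter) shows. Bringing in 3-nitrophenyl, which adds a ring, mattered more, as a number 22 percentage points lower from compound 1 to compound 2 (beyond the scatter) shows. The new group in compound 4 adds no ring, so the first of these is the closer guide, although it rests on a single pair of compounds.

The expected result is a number 3 percentage points lower from compound 3 to compound 4 (within the scatter), which would be no clear step beyond the scatter. For compound 4 the estimated value is 62%, with an expected range of 50% to 72%.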

Compound 4, percent growth inhibition at one concentration: 75%
Compound 4: middle estimate off by 13 percentage points, on the low side; measured number above the stated range.
By their numbers in this assay, from the lowest: compound 2; then compounds 3, 1 and 4 (each within the scatter of the next).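

On this oxygen on an aromatic ring, the propargyl group keeps the growth inhibition of the two smaller groups in this assay: the steps are a number 10 percentage points higher from compound 3 to compound 4 (within the scatter) and a number 7 percentage points higher from compound 1 to compound 4 (within the scatter), so compound 1, compound 3 and compound 4 cannot be told apart. Among the compounds shown here, the contrast with the ring-bearing group is now larger, at a number 29 percentage points higher from compound 2 to compound 4 (beyond the scatter), and compound 2 remains the only compound that stands apart from the others. No measurement shown gives a reason for these numbers.

The compounds shown leave open how a longer chain, such as butyl, or a chain ending in an amine would fare on this oxygen. They also leave open whether the number for compound 2 reflects any added ring or 3-nitrophenyl in particular, a question that plain phenyl could help to separate.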